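Benzyl ether to butyl ether on a shared core

The compounds below may be only part of what the source reports. "The series", "measured", "known", "first", "only" and "open" are said of these compounds alone.

Compound 1 `COc1cccc(OCCC(C)(C)C)c1C(=O)/C=C/c1ccc(O)cc1` — > 30000 nM
Compound 2 `O=C(/C=C/c1ccc(O)cc1)c1c(O)cccc1OCc1ccccc1` — > 30000 nM

Of the compounds shown here, two have so far been tested in a functional assay on PC-3 cells (Homo sapiens) for antiproliferative activity, read by sulforhodamine B assay; on this read-out lower numbers stand for stronger inhibition of growth and higher numbers for weaker inhibition of growth. Compound 1 `COc1cccc(OCCC(C)(C)C)c1C(=O)/C=C/c1ccc(O)cc1` gives no number in this assay, only the limit > 30000 nM. Compound 2 `O=C(/C=C/c1ccc(O)cc1)c1c(O)cccc1OCc1ccccc1` likewise stops at the limit > 30000 nM. So compound 2 stands where the only other measured compound stands: the limit of > 30000 nM in this assay, at which 2 of the 2 values shown sit. For the measured compounds named here, no pair of measured compounds differs in a single place, and so no measured step exists that would show how large an effect any one change in structure has in this assay.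

Compound 3 `CCCCOc1cccc(O)c1C(=O)/C=C/c1ccc(O)cc1` is the compound still to be measured. It differs from compound 2 in one place: propyl in place of phenyl on a saturated chain carbon bound to an oxygen on an aromatic ring. With both measured values being limits, no direction can be read from the data for this change. The step is expected to be a step that the limit leaves unreadable from compound 2 to compound 3, that is, none beyond the scatter, with a real chance that the assay again returns only a limit. Compound 3 is estimated at 40000 nM, within a range from 8000 nM to 200000 nM.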

Compound 3, concentration for 50% growth inhibition: > 30000 nM
Compound 3: only a limit was reported; the forecaster's own chance of this, stated with the estimate: 70%; the middle value lies beyond the limit too.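

In this assay compound 3 gives only a limit, > 30000 nM. The change from benzyloxy to butoxy between compound 2 and compound 3 therefore cannot be read as a step, and all the compounds shown share one result: the limit of > 30000 nM in this assay, at which 3 of the 3 values shown sit.

The compounds shown leave open which change to the shared core, if any, would give a measurable value in this assay.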